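Cell Tolerance When a Large Side Group Shrinks

The source may report more compounds than this note shows. Statements on the series, on what has been measured and on what is new or still open speak of the compounds shown alone.

Measured in an ADME assay on Vero cells (Chlorocebus sabaeus) for cytotoxicity, read by MTT assay, with a stated time of 72 h; a higher number here means that more compound is tolerated, a lower number that less compound is tolerated:
- compound 1 `COc1c(N2CCN(CC#N)C(C)C2)c(F)cc2c(=O)c(C(=O)O)cn(C3CC3)c12` gives 354 ug/mL
- compound 2 `CO/N=C(\C)CN1CCN(c2c(F)cc3c(=O)c(C(=O)O)cn(C4CC4)c3c2OC)CC1C` gives 49.6 ug/mL
- compound 3 `COc1c(N2CCN(C/C(C)=N/NC(=O)c3ccncc3)C(C)C2)c(F)cc2c(=O)c(C(=O)O)cn(C3CC3)c12` gives 250 ug/mL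

The data show a 1.4-fold lower number from compound 1 to compound 3 (0.15 log units; within the scatter), so compound 3 and compound 1 cannot be told apart here. They also show a 5.0-fold higher number from compound 2 to compound 3 (0.70 log units; beyond the scatter), which separates compound 3 clearly from compound 2.

Compound 4 `COc1c(N2CCN(CC/C(C)=N/O)C(C)C2)c(F)cc2c(=O)c(C(=O)O)cn(C3CC3)c12` is still unmeasured. The change is a group of 5 heavy atoms (3 carbon, 1 nitrogen, 1 oxygen; no ring) in place of a group of 12 heavy atoms (8 carbon, 3 nitrogen, 1 oxygen; one six-membered aromatic ring with 1 hetero atom), on a saturated chain carbon bound to an amine nitrogen in a ring, so the six-membered aromatic ring leaves and the group that enters has no ring.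

Compound 2 is the closest guide, as it also carries a group of 5 heavy atoms with no ring at this place. Read backwards, its step to compound 3 points to a lower number for compound 4. Compound 1 goes against any simple link with group size, as its small group comes with 354 ug/mL, so a smaller drop seems wiser.

The expected step is a 2.5-fold lower number from compound 3 to compound 4 (0.40 log units; beyond the scatter), meaning less compound tolerated in this assay. The estimate for compound 4 is 100 ug/mL, with an expected range from 40 ug/mL to 260 ug/mL.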

Compound 4, half-maximal cytotoxic concentration: 44.2 ug/mL
Compound 4: the middle estimate sits 2.3-fold (0.35 log units) above what was measured; the measured number falls inside the stated range.
By their numbers in this assay, from the lowest: compounds 4 and 2 (each within the scatter of the next); then compounds 3 and 1 (each within the scatter of the next).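

In this assay there is a 5.7-fold lower number from compound 3 to compound 4 (0.75 log units; beyond the scatter), so at this saturated chain carbon, swapping the group of 12 heavy atoms with its six-membered aromatic ring for the smaller group lowers the tolerated amount. There is also a 1.1-fold lower number from compound 2 to compound 4 (0.05 log units; within the scatter), so two different groups of 5 heavy atoms cannot be told apart here, and an 8.0-fold lower number from compound 1 to compound 4 (0.90 log units; beyond the scatter) sets both apart from the group of 2 heavy atoms. Tolerance therefore does not track group size in these compounds: compound 1 and compound 3, with the smallest and largest groups, both stand high, and no measurement here offers a reason.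

As far as these compounds go, it stays open where an amine, a carboxylic acid or a longer chain at this place would fall. It is also unclear whether the six-membered aromatic ring or the rest of the group of 12 heavy atoms goes with the higher number of compound 3.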